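Removing the aryl methyl: compound 3 to compound 4

A few compounds are considered here, and "the series" means these few. Any claim that something is new, unique, unknown or untested is made for them only; others in the source may bear on it.

Within the data shown here, compound 3 `Cc1cccc(C2CNCC2C(=O)Nc2cc3cc[nH]c(=O)c3cc2Cl)c1` gives 5 nM in an assay on isolated protein for inhibition of Rho-associated protein kinase 2 (Homo sapiens), read by a luciferase reporter (on this read-out higher numbers stand for weaker inhibition and lower numbers for stronger inhibition), the lowest of the three numbers so far. Compound 1 `O=C(Nc1cc2cc[nH]c(=O)c2cc1Cl)C1CNCC1c1ccc(F)cc1` stands nearest with 9 nM in this assay, a gap within the scatter: a 1.8-fold lower number from compound 1 to compound 3 (0.26 log units; within the scatter). Compound 2 `CC(C)(C)c1cccc(C2CNCC2C(=O)Nc2cc3cc[nH]c(=O)c3cc2Cl)c1` gives 11 nM in this assay, a modest gap: a 2.2-fold lower number from compound 2 to compound 3 (0.34 log units; beyond the scatter). Compound 4 `O=C(Nc1cc2cc[nH]c(=O)c2cc1Cl)C1CNCC1c1ccccc1` differs from compound 3 by hydrogen in place of methyl on an aromatic carbon. Among the measured compounds shown here, no measured step removes a group from this ring outright; the nearest are a 2.2-fold lower number from compound 2 to compound 3 (0.34 log units; beyond the scatter), which shrank the group, and a 1.2-fold higher number from compound 1 to compound 2 (0.09 log units; within the scatter), which exchanged the whole aryl group and stayed within the scatter. With such small movements, only a small step is expected: a 1.6-fold higher number from compound 3 to compound 4 (0.20 log units; within the scatter). Compound 4 is estimated at 8 nM, with a range from 3 nM to 20 nM in this assay.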

Compound 4, half-maximal inhibitory concentration: 6 nM
Compound 4: the middle estimate sits 1.3-fold (0.12 log units) above what was measured, within the range that was stated.
By their numbers in this assay, from the lowest: compounds 3, 4, 1 and 2 (each within the scatter of the next, the first and the last beyond it).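

In this assay, taking the methyl off to leave plain phenyl changes little: a 1.2-fold higher number from compound 3 to compound 4 (0.08 log units; within the scatter). Plain phenyl also stays within the scatter of the two other aryl groups, a 1.8-fold lower number from compound 2 to compound 4 (0.26 log units; within the scatter) and a 1.5-fold lower number from compound 1 to compound 4 (0.18 log units; within the scatter), so neither fluoro, methyl nor tert-butyl gives a step from hydrogen beyond the scatter, and no substituent on this ring is required for the low number of compound 4. No measurement at hand explains this flat behaviour.

Going by these compounds, whether an amine or a carboxylic acid on this ring would move the number beyond the scatter stays open. So does the effect of replacing the phenyl with a pyridine.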